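Fluoro in place of bromo: outlook for compound 3

The source may report more compounds than this note shows. Statements on the series, on what has been measured and on what is new or still open speak of the compounds shown alone.

In a functional assay on the whole organism (strain Kunming) with Mus musculus as the target, with a stated time of 0.5 h (on this read-out higher numbers stand for an effect only at larger amounts of compound and lower numbers for an effect already at smaller amounts), compound 1 (`COc1cc(OC)c(OC)cc1/C=C/COC(=O)/C=C/c1c(OC)ccc(OC)c1OC`) gives 120 umol/kg. Compound 2 (`COc1cc(OC)c(OC)cc1/C=C/COC(=O)/C=C/c1ccc(Br)cc1`) gives 143 umol/kg, and these two numbers lie within the usual scatter of each other. Compound 3 (`COc1cc(OC)c(OC)cc1/C=C/COC(=O)/C=C/c1ccc(F)cc1`) has fluoro in place of bromo on an aromatic carbon, para to a large group: fluoro in place of bromo on an aromatic carbon. For the measured compounds named here, no measured pair isolates this change, so no step beyond the scatter is expected in this assay. The estimated outcome is a 1.0-fold higher number from compound 2 to compound 3 (0.02 log units; within the scatter). For compound 3 the expected value is 150 umol/kg, with an estimated range of 70 umol/kg to 320 umol/kg.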

Compound 3, dose for half-maximal effect: 92.9 umol/kg
Compound 3: middle estimate off by 1.6-fold (0.21 log units), on the high side; the range from low to high includes it.
By their numbers in this assay, from the lowest: compounds 3, 1 and 2 (each within the scatter of the next).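

For the compounds shown here, the step of a 1.5-fold lower number from compound 2 to compound 3 (0.19 log units; within the scatter) in this assay is the first comparison that differs in one place, and it shows that, on this aromatic carbon para to a large group, fluoro in place of bromo brings no step beyond the scatter. No measurement at hand explains this result. Going by these compounds, it remains open whether a group other than a halogen at this place, such as an amine or a carboxylic acid, would give a step beyond the scatter.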